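The source may hold more compounds than are shown below. What is called first, only, known or untested is meant among the compounds shown, and "the series" means these compounds.

Three compounds share one core and were tested in a functional assay on MCF7 cells (Homo sapiens) for cytotoxicity, read by MTT assay, with a stated time of 72 h; on this read-out higher numbers stand for weaker inhibition and lower numbers for stronger inhibition. Compound 1 `Cc1ccc(-n2nc(C(=O)Nc3ccc(Oc4ncnc5ccsc45)cc3)c(C)cc2=O)cc1` gives 23800 nM. Compound 2 `Cc1cc(=O)n(-c2ccc(F)cc2)nc1C(=O)Nc1ccc(Oc2ncnc3ccsc23)cc1` gives 4400 nM in this assay, and compound 3 `Cc1ccc(-n2nc(C(=O)Nc3ccc(Oc4ncnc5ccsc45)c(F)c3)c(C)cc2=O)cc1` gives 7250 nM. Compound 2 differs from compound 1 by fluoro in place of methyl on an aromatic carbon, and this gave a 5.4-fold lower number from compound 1 to compound 2 (0.73 log units; beyond the scatter). Compound 3 differs from compound 1 by fluoro in place of hydrogen on an aromatic carbon, which gave a 3.3-fold lower number from compound 1 to compound 3 (0.52 log units; beyond the scatter). Between compound 2 and compound 3 no step is counted here; their two values lie within the scatter of each other.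

Compound 4 `Cc1cc(=O)n(-c2ccc(F)cc2)nc1C(=O)Nc1ccc(Oc2ncnc3ccsc23)c(F)c1` has not yet been measured in this assay. It differs from compound 3 by fluoro in place of methyl on an aromatic carbon, the same change as from compound 1 to compound 2, at the same place. The core of compound 3 differs from that of compound 1 by the fluoro in place of hydrogen described above. For the measured compounds named here, the expectation rests on the one earlier instance: because a 5.4-fold lower number from compound 1 to compound 2 (0.73 log units; beyond the scatter) was a modest step beyond the scatter, a step of about a 4.8-fold lower number from compound 3 to compound 4 (0.68 log units; beyond the scatter) is expected here, somewhat less certain since only one such case exists. Compound 4 is thus estimated at 1500 nM, likely between 600 nM and 4000 nM.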

Compound 4, half-maximal inhibitory concentration: 740 nM
Compound 4: the middle estimate sits 2.0-fold (0.31 log units) above what was measured, and the stated range covers the measured number.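

In this assay, for the compounds shown here, fluoro in place of methyl on the second core gave a 9.8-fold lower number from compound 3 to compound 4 (0.99 log units; beyond the scatter), and this step agrees with the one seen earlier on the first core: the same change on two cores in this assay, a 5.4-fold lower number (0.73 log units; beyond the scatter) from compound 1 to compound 2 and a 9.8-fold lower number (0.99 log units; beyond the scatter) from compound 3 to compound 4, 1.8-fold (0.26 log units) apart, within the scatter of two such steps Fluoro in place of hydrogen on an aromatic carbon also carried over, giving a 5.9-fold lower number from compound 2 to compound 4 (0.77 log units; beyond the scatter), in line with the same change made on the 4-methylphenyl compounds: the same change on two cores in this assay, a 3.3-fold lower number (0.52 log units; beyond the scatter) from compound 1 to compound 3 and a 5.9-fold lower number (0.77 log units; beyond the scatter) from compound 2 to compound 4, 1.8-fold (0.26 log units) apart, within the scatter of two such steps Each change therefore lowered the number on both cores by amounts that cannot be told apart, but this rests on only two pairs per change and does not show that either step would carry to other cores, nor does it explain why the number falls.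

The compounds shown leave open whether a chloro, methoxy or amine group in place of the methyl would lower the number further. They also leave open whether the two changes would keep this agreement in any read-out other than this assay.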